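A few compounds are considered here, and "the series" means these few. Any claim that something is new, unique, unknown or untested is made for them only; others in the source may bear on it.

Series notes, step from compound 2 to compound 4.

Three compounds of the shared core have numbers in an assay on membranes from brain for binding affinity to adenosine receptor A1 (Rattus norvegicus), read by radioligand binding, tested at 20 uM; a higher number here means more inhibition at the concentration tested (going by the name of the read-out), a lower number less inhibition. Compound 1 `Cn1c(=O)[nH]c2c(cnn2-c2ccccc2[N+](=O)[O-])c1=N` gives 5% in this assay. Compound 2 `Cn1c(=O)[nH]c2c(cnn2-c2ccc(Cl)cc2)c1=N` gives 37%. Compound 3 `CCCn1c(=O)[nH]c2c(cnn2-c2cccc(Cl)c2)c1=N` differs from compound 2 in several places at once. In this assay compound 3 gives 68%. Compound 2 thus stands in the middle of the three: the number for compound 3 lies higher by a gap beyond the usual scatter, and the number for compound 1 lies lower, also by a gap beyond the scatter. Compounds 1 and 3 both differ from compound 2 in several places at once, so no single change among the measured compounds can be read as a step.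

The next compound, compound 4 `Cn1c(=O)[nH]c2c(cnn2-c2ccc(N)cc2)c1=N`, differs from compound 2 in one place only: amino in place of chloro on an aromatic carbon. Among the measured compounds shown here, no measured pair shows what this exchange does in this assay. With nothing to go on but the shared core and the value of compound 2, the expectation is a step of modest size, most likely downward or none beyond the scatter; a step from compound 2 to compound 4 of about a number 12 percentage points lower from compound 2 to compound 4 (beyond the scatter) is expected. For compound 4 the estimated inhibition in this assay is 25%, with a range from 5% to 55%.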

Compound 4, a percentage reported as inhibition, at one concentration (the size of the read-out at that concentration, not a potency): 0%
Compound 4: the middle estimate sits 25 percentage points above what was measured; measured number below the stated range.
By their numbers in this assay, from the lowest: compounds 4 and 1 (each within the scatter of the next); then compound 2; then compound 3.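

In this assay, among the compounds shown here, the exchange of chloro for amino on an aromatic carbon, para to a large group, gives the first single change that can be read, and the reading is a number 37 percentage points lower from compound 2 to compound 4 (beyond the scatter), a large step. The position is thus not indifferent to its substituent: with the rest of the structure held fixed, compound 2 with chloro gives 37% at the concentration tested, whereas compound 4 with amino gives 0% in the same test, so this one-atom exchange is enough to remove the inhibition seen with chloro. No measurement among the data shown bears on why the exchange has this effect, and the step stands as an observation only.

The compounds shown leave open how other groups at this position compare, such as fluoro, bromo, methyl, methoxy or hydroxy, and whether an acetylated amine would give a number closer to that of chloro or of amino. Also open, going by these compounds, is whether the same exchange gives a step of similar size on a core carrying a propyl chain in place of the methyl group, since this step rests on a single pair.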